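From fluoro to tert-butoxy on a shared core

The source may report more compounds than this note shows. Statements on the series, on what has been measured and on what is new or still open speak of the compounds shown alone.

Measured so far in a functional assay on A549 cells (Homo sapiens) for inhibition, read by MTT assay, with a stated time of 72 h; on this read-out lower numbers stand for stronger inhibition and higher numbers for weaker inhibition:
- compound 1 `O=[N+]([O-])c1ccc(-c2nnc(SCCCN3CCN(c4nc5ccccc5s4)CC3)o2)cc1`: 96600 nM
- compound 2 `Fc1ccc(-c2nnc(SCCCN3CCN(c4nc5ccccc5s4)CC3)o2)cc1`: 71700 nM

Only these two compounds have been measured, and their values do not separate. The change between them is fluoro in place of nitro on an aromatic carbon, and it amounts to a 1.3-fold lower number from compound 1 to compound 2 (0.13 log units; within the scatter). Compound 2 therefore stands level with compound 1, with no real ranking between them.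

Compound 3 `CC(C)(C)Oc1ccc(-c2nnc(SCCCN3CCN(c4nc5ccccc5s4)CC3)o2)cc1` keeps the core of compound 2 and alters one group: tert-butoxy in place of fluoro on an aromatic carbon. This places tert-butoxy in place of fluoro on an aromatic carbon, para to a large group.

Among the measured compounds shown here, the only measured change at this carbon is the one already described, and it stayed within the scatter. For the measured compounds named here, no measured compound carries tert-butoxy, so this is a thin guide and it points in neither direction. With that caution, and resting on a 1.3-fold lower number from compound 1 to compound 2 (0.13 log units; within the scatter), no shift beyond the scatter is expected in this assay. The expected step is a 1.0-fold lower number from compound 2 to compound 3 (0.01 log units; within the scatter). For compound 3 the estimated value is 70000 nM, with an expected range from 30000 nM to 160000 nM.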

Compound 3, half-maximal inhibitory concentration: 71600 nM
For compound 3 the middle estimate is 1.0-fold (0.01 log units) below the measured one; low and high end bracket the measured number.
By their numbers in this assay, from the lowest: compounds 3, 2 and 1 (each within the scatter of the next).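

In this assay, the exchange at this aromatic carbon, para to a large group, brings in tert-butoxy with 5 heavy atoms and 1 hydrogen-bond acceptor for fluoro with 1 heavy atom and no hydrogen-bond acceptor, and it gives a 1.0-fold lower number from compound 2 to compound 3 (0.00 log units; within the scatter). Among the compounds shown here, exchanging nitro for tert-butoxy at the same carbon gives a 1.3-fold lower number from compound 1 to compound 3 (0.13 log units; within the scatter), so three different groups at this position now stand level, where the earlier compounds offered only two, and a difference in heavy-atom count of this size has not separated the values in this assay. Nothing available explains why these values stay level.

As far as these compounds go, whether any group at this carbon can move the number beyond the scatter remains open, for instance an amine or a carboxylic acid in place of tert-butoxy. The compounds shown also change only this one position, so they leave open whether a longer chain on the shared core would have any effect in this assay.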